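Pyridine triaryl series: moving from compound 2 to compound 3

The compounds below may be only part of what the source reports. "The series", "measured", "known", "first", "only" and "open" are said of these compounds alone.

Measured so far:
compound 1 `Oc1cccc(-c2cc(-c3ccccc3F)cc(-c3ccccc3O)n2)c1` with 35600 nM
compound 2 `Oc1cccc(-c2cc(-c3ccccc3F)cc(-c3cccc(O)c3)n2)c1` with 11200 nM

In a functional assay on DU-145 cells (Homo sapiens) for inhibition (on this read-out lower numbers stand for stronger inhibition and higher numbers for weaker inhibition), compound 2 gives the lower of the two numbers seen; compound 1 sits a 3.2-fold lower number from compound 1 to compound 2 (0.50 log units; beyond the scatter) away. Compound 3 `Oc1cccc(-c2cc(-c3cccc(C(F)(F)F)c3)cc(-c3cccc(O)c3)n2)c1` differs from compound 2 only by 3-(trifluoromethyl)phenyl in place of 2-fluorophenyl on an aromatic carbon. Among the measured compounds shown here, no measured step touches this position: the one known step, a 3.2-fold lower number from compound 1 to compound 2 (0.50 log units; beyond the scatter), concerns the hydroxyphenyl groups alone, and both measured compounds carry the same 2-fluorophenyl group. The change is therefore unanchored, and no step beyond the scatter is expected. Compound 3 is estimated at 10000 nM (range 3000 nM to 35000 nM), a step of a 1.1-fold lower number from compound 2 to compound 3 (0.05 log units; within the scatter) that is expected to stay within the scatter.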

Compound 3, half-maximal inhibitory concentration: > 50000 nM
Compound 3: only a limit was reported (the forecaster's own chance of this, stated with the estimate: 10%); at least 5.0-fold (0.69 log units) between middle value and limit.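

The position opposite the ring nitrogen, the same in compound 1 and compound 2, proves not to be neutral: 3-(trifluoromethyl)phenyl in place of 2-fluorophenyl gives an at least 4.4-fold higher number from compound 2 to compound 3 (0.64 log units; beyond the scatter). In this assay compound 3 gives > 50000 nM, which is a limit of the assay and not a number. The step therefore has no upper end: the limit of > 50000 nM in this assay, at which 1 of the 3 values shown sits.

The compounds shown do not separate the effect of the trifluoromethyl group from that of its place on the phenyl ring. On these data alone, how a plain phenyl, an amine or a carboxylic acid at this position would read remains open.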